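This account rests on a few compounds, and the source may have more. Where it says the series, first, only, none or still open, it means among the compounds named here.

Compound 1 `O=C(O)c1cc(-c2ccc(-c3ccc(Cl)cc3Cl)cc2)n(-c2ccc(Cl)cc2Cl)n1` gives 11900 nM in an assay on isolated protein for inhibition of methionine--tRNA ligase, cytoplasmic (Homo sapiens); a higher number here means a weaker inhibitor, a lower number a stronger inhibitor. Among the compounds with values here, compound 2 `O=C(O)c1cc(-c2ccc(-c3ccc(Cl)cc3Cl)cc2)n(-c2cccnc2)n1` gives 47000 nM in this assay, the higher of the two numbers so far, separated from compound 1 by a 3.9-fold higher number from compound 1 to compound 2 (0.60 log units; beyond the scatter). Compound 3 `O=C(O)c1cc(-c2ccc(-c3ccc(Cl)cc3Cl)cc2)n(-c2ccccn2)n1` differs from compound 2 by pyridin-2-yl in place of pyridin-3-yl on an aromatic nitrogen. Within the data shown here, no measured step covers a shift of the ring nitrogen within the pyridyl at this position; the one step available, a 3.9-fold higher number from compound 1 to compound 2 (0.60 log units; beyond the scatter), concerns a different exchange there and is only modest. Compound 3 is therefore expected to show a step of a 1.0-fold lower number from compound 2 to compound 3 (0.02 log units; within the scatter) within the scatter, with an estimated 45000 nM (range 15000 nM to 140000 nM).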

Compound 3, half-maximal inhibitory concentration: > 100000 nM
Compound 3: a limit, no number; the forecaster's own chance of this, stated with the estimate: 20%; middle value at least 2.2-fold (0.34 log units) away from the limit.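

Pyridin-2-yl and pyridin-3-yl are not interchangeable at this position in this assay, with an at least 2.1-fold higher number from compound 2 to compound 3 (0.32 log units; beyond the scatter), so the place of the ring nitrogen matters here and not only the loss of the 2,4-dichlorophenyl. Against 2,4-dichlorophenyl, pyridin-2-yl gives an at least 8.4-fold higher number from compound 1 to compound 3 (0.92 log units; beyond the scatter). For compound 3 the read-out is a limit and not a number: the limit of > 100000 nM in this assay, at which 1 of the 3 values shown sits.

Going by these compounds, how far compound 3 lies beyond its limit stays open. So does whether pyridin-4-yl, unsubstituted phenyl or an aminophenyl on this nitrogen would come closer to compound 1.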